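A few compounds are considered here, and "the series" means these few. Any claim that something is new, unique, unknown or untested is made for them only; others in the source may bear on it.

Working notes. Compound 1 `CCNC(=O)Nc1nc2cc(-c3cccnc3)cc(-c3ccccn3)c2[nH]1` gives 12.5 mL/min/kg in an ADME assay on the whole organism for pharmacokinetics, with Rattus norvegicus as the target, given by the intravenous route; a higher number here means faster removal of the compound, a lower number slower removal. Compound 2 `CCNC(=O)Nc1nc2cc(-c3cccnc3)cc(-c3ncccc3F)c2[nH]1` gives 14 mL/min/kg in this assay; the step of a 1.1-fold higher number from compound 1 to compound 2 (0.05 log units; within the scatter) leaves the pair within the scatter, and on the numbers shown compound 2 sits among two measured values only. Compound 3 `CCNC(=O)Nc1nc2cc(-c3cnc(C(C)(C)O)nc3)cc(-c3ncccc3F)c2[nH]1` carries 2-(1-hydroxy-1-methylethyl)pyrimidin-5-yl in place of pyridin-3-yl on an aromatic carbon. Going by the values given here, the sole measured step, a 1.1-fold higher number from compound 1 to compound 2 (0.05 log units; within the scatter), touches a different position, so no measured step bears on this replacement. The expected step of a 1.2-fold lower number from compound 2 to compound 3 (0.07 log units; within the scatter) is accordingly not beyond the scatter, with wide uncertainty. Compound 3 is estimated at 12 mL/min/kg in this assay, range 5 mL/min/kg to 30 mL/min/kg.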

Compound 3, clearance: 23 mL/min/kg
Compound 3: middle estimate off by 1.9-fold (0.28 log units), on the low side, within the range that was stated.
By their numbers in this assay, from the lowest: compounds 1, 2 and 3 (each within the scatter of the next).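

Placing 2-(1-hydroxy-1-methylethyl)pyrimidin-5-yl in place of pyridin-3-yl gives a 1.6-fold higher number from compound 2 to compound 3 (0.22 log units; within the scatter) in this assay. Going by these compounds alone, this is the first measured change at the position para to a fused ring, and a group of 10 heavy atoms in place of 6 leaves the read-out within the scatter. Nothing available explains the size of this step.

Going by these compounds, the pyrimidine ring and the 1-hydroxy-1-methylethyl group enter together, so their separate contributions stay open. Also open, on these data alone, is whether an amine or a carboxylic acid on that ring would give a step beyond the scatter.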